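Methoxy in place of cyano: from compound 3 to compound 4

The compounds below may be only part of what the source reports. "The series", "measured", "known", "first", "only" and "open" are said of these compounds alone.

Compound 3 `CC(O)(C(=O)Nc1ccc(C(=O)c2ccccc2)cc1C#N)C(F)(F)F` carries a hydroxy amide bearing a trifluoromethyl group on its core. In a functional assay (Cavia porcellus) with sulfonylurea receptors; K-ATP channels (Homo sapiens) as the target (on this read-out higher numbers stand for weaker inhibition and lower numbers for stronger inhibition), compound 3 gives 3800 nM. Of the two numbers reported, this is the highest; the nearest is compound 1 `Cc1cc(NC(=O)C(C)(O)C(F)(F)F)ccc1S(=O)(=O)c1ccccc1`, which in this assay gives 1600 nM, a gap beyond the scatter. Compound 2 `CC(O)(C(=O)Nc1ccc(S(=O)(=O)c2ccccc2)c([N+](=O)[O-])c1)C(F)(F)F` reaches only the limit of the assay, > 30000 nM, which is a limit and not a number; the limit of > 30000 nM in this assay, at which 1 of the 3 values shown sits, marks where it sits.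

The single measured step runs between two of these compounds: an at least 18-fold higher number from compound 1 to compound 2 (1.27 log units; beyond the scatter). It exchanges one group for another on an aromatic carbon of the shared core and weakens inhibition strongly.

Compound 4 `COc1cc(C(=O)c2ccccc2)ccc1NC(=O)C(C)(O)C(F)(F)F` differs from compound 3 in one place: methoxy in place of cyano on an aromatic carbon. Among the measured compounds shown here, the measured step concerns a different pair of groups, so it does not speak directly to this exchange, and no measured pair ties cyano to methoxy here. For compound 4 the expected step is a 1.3-fold lower number from compound 3 to compound 4 (0.10 log units; within the scatter), which is expected to fall within the scatter rather than beyond it. Compound 4 is accordingly estimated at 3000 nM, within a range from 1000 nM to 10000 nM.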

Compound 4, half-maximal inhibitory concentration: 6100 nM
The estimate for compound 4 lay 2.0-fold (0.31 log units) below the measured number; low and high end bracket the measured number.
By their numbers in this assay, from the lowest: compound 1; then compounds 3 and 4 (each within the scatter of the next). At a limit, above all of these: compound 2.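

In this assay, methoxy in place of cyano on this aromatic carbon, ortho to a large group and meta to a benzoyl group, gives a 1.6-fold higher number from compound 3 to compound 4 (0.21 log units; within the scatter), so the read-out does not separate the two groups at this position. Among the compounds shown here, this is the first measured exchange at this position, and its outcome differs from that of the only earlier step, an at least 18-fold higher number from compound 1 to compound 2 (1.27 log units; beyond the scatter), which concerned a different pair of groups, nitro in place of methyl, and lay beyond the scatter, whereas this one stays within it. Nothing measured among these compounds accounts for why cyano and methoxy read alike here.

The compounds shown leave open whether this position accepts groups other than these two, such as a plain hydrogen, an amine, a carboxylic acid or a longer chain like ethoxy, with results as close to those of compound 3 and compound 4 as these are to each other. They also leave open whether methoxy in place of cyano would read the same way on the core of compound 1, where the benzoyl group is absent.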